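The compounds below may be only part of what the source reports. "The series", "measured", "known", "first", "only" and "open" are said of these compounds alone.

Measured compounds:
compound 1, `O=C([C@@H]1C[C@H]1c1ccccc1)N(CCNCC1CCCCC1)c1ccc(-c2ccccc2)cc1`, 6.6 nM
compound 2, `CC[C@H](C)[C@H](N)CN(C(=O)[C@@H]1C[C@H]1c1ccccc1Cl)c1ccc(-c2ccccc2)cc1`, > 25000 nM

In a functional assay for agonist activity at G protein-coupled receptor 88 (Homo sapiens), read by HTRF and cAMP accumulation (a lower number here means that less compound is needed, a higher number that more compound is needed for the effect), compound 1 gives 6.6 nM. Compound 2 gives only a limit in this assay, > 25000 nM, so no number is known for it. Compound 2 thus stands at the limit of > 25000 nM in this assay, at which 1 of the 2 values shown sits, while compound 1 has a value well inside the measured range; the two compounds differ in more than one place, so their values only show how far apart they stand.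

Compound 3, `CC[C@H](C)[C@H](N)CN(C(=O)[C@@H]1C[C@H]1c1cccs1)c1ccc(-c2ccccc2)cc1`, follows from compound 2 by one change: thiophen-2-yl in place of 2-chlorophenyl on a saturated ring carbon. Among the measured compounds shown here, no measured step of this kind is known here, so the size of the step in this assay is uncertain. Because compound 2 sits at the limit of > 25000 nM in this assay, at which 1 of the 2 values shown sits, any gain in compound 3 would appear as a step downward in this assay; no gain would leave it at the same limit. A moderate gain is expected, with a step of an at least 6.2-fold lower number from compound 2 to compound 3 (0.79 log units; beyond the scatter). For compound 3 a value of 4000 nM is estimated, within a range from 300 nM to 25000 nM.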

Compound 3, half-maximal effective concentration: 360 nM
Compound 3: the middle estimate sits 11-fold (1.05 log units) above what was measured, within the range that was stated.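

In this assay, among the compounds shown here, the result gives the first measured step at this place, a saturated ring carbon of the three-membered ring: thiophen-2-yl in place of 2-chlorophenyl brings an at least 69-fold lower number from compound 2 to compound 3 (1.84 log units; beyond the scatter). With the rest of the structure unchanged, this one exchange moves the compound from a limit to a measured value, so the group on this carbon clearly matters in this pair. Compound 2 stands only at a limit, so the step gives only a bound on its size: the limit of > 25000 nM in this assay, at which 1 of the 3 values shown sits.

On these data alone, whether the gain goes with losing the chlorine or with the thiophen-2-yl ring itself stays open; a plain phenyl on this carbon, with the same side chain, would separate the two. Also open, as far as these compounds go, is how the side chain of compound 3 relates to that of compound 1, which gives 6.6 nM, since these two differ in more than one place.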